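The source may hold more compounds than are shown below. What is called first, only, known or untested is meant among the compounds shown, and "the series" means these compounds.

Measured compounds in an ADME assay on HEK293 cells for displacement of a labelled ligand from 5-hydroxytryptamine receptor 6 (Homo sapiens), read by radioligand binding, with a stated time of 1 h; a higher number here means a weaker inhibitor, a lower number a stronger inhibitor:
- compound 1, `O=C1c2ccccc2S(=O)(=O)N1CCCCCCN1CCN(c2ccccc2Cl)CC1`, compound 1 gives 459 nM
- compound 2, `O=C1c2ccccc2S(=O)(=O)N1CCCCCCN1CCN(c2ccccc2F)CC1`, compound 2 gives 1620 nM
- compound 3, `O=C1c2ccccc2S(=O)(=O)N1CCCCCCN1CCN(c2cccc(Cl)c2Cl)CC1`, compound 3 gives 920 nM

Compound 3 stands second highest of the three numbers. Its nearest neighbour is compound 2, with a 1.8-fold lower number from compound 2 to compound 3 (0.25 log units; within the scatter), and its furthest is compound 1, with a 2.0-fold higher number from compound 1 to compound 3 (0.30 log units; within the scatter); neither gap is beyond the scatter. Within the data shown here, the only step beyond the scatter in this set is a 3.5-fold higher number from compound 1 to compound 2 (0.55 log units; beyond the scatter).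

Compound 4, `COc1cccc(N2CCN(CCCCCCN3C(=O)c4ccccc4S3(=O)=O)CC2)c1`, is not yet measured. It differs from compound 3 as follows: 3-methoxyphenyl in place of 2,3-dichlorophenyl on an amine nitrogen in a ring.

Among the measured compounds shown here, the steps that bear on this change are all exchanges of the group on the same ring nitrogen. Two of them, a 2.0-fold higher number from compound 1 to compound 3 (0.30 log units; within the scatter) and a 1.8-fold lower number from compound 2 to compound 3 (0.25 log units; within the scatter), stayed within the scatter; one, a 3.5-fold higher number from compound 1 to compound 2 (0.55 log units; beyond the scatter), was modest. For the measured compounds named here, no measured step involves a methoxy group, so the direction for compound 4 is uncertain. A modest move toward a higher number is expected for compound 4, as a 1.6-fold higher number from compound 3 to compound 4 (0.21 log units; within the scatter), with a wide range.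

Compound 4 is estimated at 1500 nM in this assay, expected between 450 nM and 5000 nM.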

Compound 4, inhibition constant: 921 nM
Beside the measured number, compound 4's estimate is 1.6-fold (0.21 log units) above it, and the stated range covers the measured number.
By their numbers in this assay, from the lowest: compounds 1, 3, 4 and 2 (each within the scatter of the next, the first and the last beyond it).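

In this assay, 3-methoxyphenyl in place of 2,3-dichlorophenyl on the ring nitrogen gives a step within the scatter (a 1.0-fold higher number from compound 3 to compound 4 (0.00 log units; within the scatter)), so a group with one hydrogen-bond acceptor and no chlorine can stand at this position without a step beyond the scatter from the dichlorophenyl compound. Among these compounds, compound 4 also lies within the scatter of both 2-halophenyl compounds (a 1.8-fold lower number from compound 2 to compound 4 (0.25 log units; within the scatter); a 2.0-fold higher number from compound 1 to compound 4 (0.30 log units; within the scatter)), so the exchange of chloro for fluoro remains the only change in the set that gives a step beyond the scatter, and the methoxy compound does not sort with either side of it. No measured data on the compounds bear on why these steps are as small as they are.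

The compounds shown leave open whether the place of the substituent on the phenyl ring matters apart from its identity, which 2-methoxyphenyl or 3-chlorophenyl on the same ring nitrogen would test. They also leave open how far the read-out depends on the rest of the molecule, such as a shorter chain joining the two ends, or a hydroxyl or an amine on the phenyl ring in place of methoxy.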